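Swapping a Ring for a Branched Chain on the Amide

The compounds below may be only part of what the source reports. "The series", "measured", "known", "first", "only" and "open" are said of these compounds alone.

Compound 1 `O=C(NC1(C(=O)O)CCCCC1)c1cccc2c(Br)c(-c3ccc(Cl)cc3)oc12` was tested in an assay on isolated protein for inhibition of endoplasmic reticulum aminopeptidase 2 (Homo sapiens); on this read-out lower numbers stand for stronger inhibition and higher numbers for weaker inhibition. Compound 1 gives > 30000 nM, which is a limit of the assay rather than a number. Compound 2 `O=C(NC1(C(=O)O)CCCC1)c1cc(F)cc2cc(-c3ccc(Cl)cc3)oc12` gives > 30000 nM in this assay, again a limit. Compound 1 thus stands where every measured value stands: the limit of > 30000 nM in this assay, at which 2 of the 2 values shown sit. Compound 3 `CC(C)(NC(=O)c1cccc2c(Br)c(-c3ccc(Cl)cc3)oc12)C(=O)O` differs from compound 1 in one place: 1-carboxy-1-methylethyl in place of 1-carboxycyclohexyl on an amide-type nitrogen. Among the compounds with values here, no step between measured compounds is available; the step of a number no higher from compound 1 to compound 3 (the limit leaves the size open) is expected to stay within the scatter. Compound 3 is therefore expected to give about 30000 nM in this assay, within 10000 nM to 100000 nM.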

Compound 3, half-maximal inhibitory concentration: > 30000 nM
Compound 3: only a limit was reported; the forecaster's own chance of this, stated with the estimate: 80%; the middle value lies on the limit itself.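

Compound 3 gives > 30000 nM in this assay, which is a limit and not a number. Within the data shown here, compound 1 also stands at a limit, so no step between compound 1 and compound 3 can be read. The compounds shown leave open how strongly each inhibits, and what 1-carboxy-1-methylethyl in place of 1-carboxycyclohexyl changes.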